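This account rests on a few compounds, and the source may have more. Where it says the series, first, only, none or still open, it means among the compounds named here.

Of the compounds shown here, three built on the same core have been tested in a functional assay on HL-60 cells (Homo sapiens) for inhibition, read by MTT assay, with a stated time of 72 h; a higher number here means a weaker inhibitor, a lower number a stronger inhibitor. Compound 1 `COc1ccc(-c2nc(C)oc2C(=O)N2CCN(c3cccc(Cl)c3)CC2)cc1OC` gives "not active" (no number reported), so it offers no number to start from. Compound 3 `COc1ccc(-c2nc(C)oc2C(=O)N2CCN(c3cccc(Cl)c3)CC2)cc1O` also gives "not active" (no number reported), while compound 2 `Cc1nc(-c2ccccc2Cl)c(C(=O)N2CCN(c3cccc(Cl)c3)CC2)o1` gives 132 nM. Compound 4 `COc1cc(-c2nc(C)oc2C(=O)N2CCN(c3cccc(Cl)c3)CC2)ccc1OP(=O)(O)O` differs from compound 1 by one change: a group of 4 heavy atoms (3 oxygen, 1 phosphorus; no ring) in place of one carbon atom, on an oxygen on an aromatic ring, on an oxygen on an aromatic ring. Among the compounds with values here, no measured pair shows what this change does, so the size of the step cannot be calculated. The expectation is that compound 4 stays weak, resting on compound 1 at "not active" (no number reported) and compound 3 at "not active" (no number reported). The estimate for compound 4 is 5000 nM, with an expected range of 500 nM to 50000 nM.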

Compound 4, half-maximal inhibitory concentration: 303 nM
The estimate for compound 4 lay 17-fold (1.22 log units) above the measured number; the measured number lies below the stated range.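

Within the data shown here, compound 1 gives "not active" (no number reported), so it offers no number, and no step from it to compound 4 at 303 nM can be read. Why the group entering in compound 4 goes with a measurable value stays open, and nothing measured here offers an explanation.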